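Hydroxy for acetoxy, repeated on a second core

The source may hold more compounds than are shown below. What is called first, only, known or untested is meant among the compounds shown, and "the series" means these compounds.

Compound 1 `CC(O)n1cnc2c(N)nc(I)nc21` gives 465000 nM in a functional assay on CCRF-CEM cells (Homo sapiens) for inhibition; on this read-out higher numbers stand for weaker inhibition and lower numbers for stronger inhibition. Compound 2 `CC(=O)OC(C)n1cnc2c(N)nc(I)nc21` gives 381000 nM. Compound 3 `CC(=O)OC(C)n1cnc2c(S)nc(F)nc21` reaches only a limit of the assay, > 500000 nM.

Among the measured compounds shown here, the one step that can be counted among the measured compounds is hydrogen in place of acetyl on an oxygen on a saturated carbon. It produced a 1.2-fold higher number from compound 2 to compound 1 (0.09 log units; within the scatter), so the acetyl and the free hydroxy look alike on this read-out. The difference between the core of compound 2 and the core of compound 3 is not broken down here. For compound 3 the assay gives no number but a limit, (the limit of > 500000 nM in this assay, at which 1 of the 3 values shown sits).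

Compound 4 `CC(O)n1cnc2c(S)nc(F)nc21` is still to be measured. It arises from compound 3 by the same change, (hydrogen in place of acetyl on an oxygen on a saturated carbon), at the same kind of place as in the pair already measured. The expected size of the step from compound 3 to compound 4 rests on the earlier result, because the step of a 1.2-fold higher number from compound 2 to compound 1 (0.09 log units; within the scatter) stayed within the scatter, and because compound 3 stands at the limit of > 500000 nM in this assay, at which 1 of the 3 values shown sits, the new value will most likely be reported as a limit as well. Compound 4 is therefore expected to give 500000 nM, between 250000 nM and 1000000 nM, which is a step of a number no higher from compound 3 to compound 4 (the limit leaves the size open).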

Compound 4, half-maximal inhibitory concentration: > 500000 nM
Compound 4 was reported as a limit (the forecaster's own chance of this, stated with the estimate: 70%); the middle value lies on the limit itself.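

In this assay, compound 3 and compound 4 are both reported only as limits, so no step between them can be read: the limit of > 500000 nM in this assay, at which 2 of the 4 values shown sit.

The compounds shown leave open whether acetoxy to hydroxy has any measurable size on the core of compound 3, and so whether it matches the step seen on the core of compound 1.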